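This account rests on a few compounds, and the source may have more. Where it says the series, first, only, none or still open, it means among the compounds named here.

In a functional assay on PC-3 cells (Homo sapiens) for antiproliferative activity (a higher number here means a weaker inhibitor of growth, a lower number a stronger inhibitor of growth), compound 3 `Cc1cc(C)c2c(O)cc(-c3cccc(F)c3)nc2n1` gives 61.7 nM as the higher of the two numbers, while compound 1 `Cc1ccnc2nc(-c3cccc(Cl)c3)cc(O)c12` gives 15.5 nM and lies lower by more than the scatter. Compound 2 `Cc1ccc2c(O)cc(-c3cccc(Cl)c3)nc2n1` reaches only a limit (> 100000 nM). Compound 4 `Cc1cc(C)c2c(O)cc(-c3cccc(Cl)c3)nc2n1` has chloro in place of fluoro on an aromatic carbon, meta to a large group (chloro in place of fluoro on an aromatic carbon). Compound 1 carries chloro there and holds the lower number (15.5 nM), yet compound 2 also carries chloro and goes against any simple pattern. Only a modest move toward a lower number is therefore expected in this assay, near the edge of the scatter. The expected step runs a 2.1-fold lower number from compound 3 to compound 4 (0.31 log units; beyond the scatter) in this estimate. Compound 4 is estimated at 30 nM with 8 nM to 120 nM as the expected range.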

Compound 4, concentration for 50% growth inhibition: 27.5 nM
Compound 4: the middle estimate sits 1.1-fold (0.04 log units) above what was measured; low and high end bracket the measured number.
By their numbers in this assay, from the lowest: compounds 1 and 4 (each within the scatter of the next); then compound 3. At a limit, above all of these: compound 2.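

In this assay, chloro in place of fluoro gives a 2.2-fold lower number from compound 3 to compound 4 (0.35 log units; beyond the scatter) and so shows a modest gain at this place with both methyl groups present. Methyl in place of hydrogen depends on where it stands: one such change gives an at least 3600-fold lower number from compound 2 to compound 4 (3.56 log units; beyond the scatter) and the other gives a 1.8-fold higher number from compound 1 to compound 4 (0.25 log units; within the scatter) within the scatter, so the methyl absent from compound 2 counts far more than the one absent from compound 1. The first of these steps starts from a limit and not a number: the limit of > 100000 nM in this assay, at which 1 of the 4 values shown sits.

Bromo, a methoxy group or an amine at this place remain open, as does whether the chloro-for-fluoro step would hold without either methyl group.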